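Swapping the Thiophene for a Bromofuran

A few compounds are considered here, and "the series" means these few. Any claim that something is new, unique, unknown or untested is made for them only; others in the source may bear on it.

- compound 1 `COc1ccc(OC)c(C(=O)/C=C/c2ccc(C)o2)c1` gives 10300 nM
- compound 2 `COc1ccc(OC)c(C(=O)/C=C/c2ccc(C)s2)c1` gives 2600 nM

Going by the values given here, in a functional assay on MCF7 cells (Homo sapiens) for cytotoxicity, read by MTT assay (on this read-out lower numbers stand for stronger inhibition and higher numbers for weaker inhibition), compound 2 at 2600 nM holds the lower of the only two numbers so far. Compound 3 `COc1ccc(OC)c(C(=O)/C=C/c2occc2Br)c1` differs from it in one place, on a double-bonded chain carbon bound to a double-bonded chain carbon: 3-bromofuran-2-yl in place of 5-methylthiophen-2-yl on a double-bonded chain carbon bound to a double-bonded chain carbon with 3-bromofuran-2-yl in place of 5-methylthiophen-2-yl.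

Among the compounds with values here, only one measured step bears on this change. It is a 4.0-fold lower number from compound 1 to compound 2 (0.60 log units; beyond the scatter) and it is modest but beyond the scatter. That step came with 5-methylthiophen-2-yl in place of 5-methylfuran-2-yl. Compound 3 again carries a furan ring, so the reverse of a 4.0-fold lower number from compound 1 to compound 2 (0.60 log units; beyond the scatter) points to a higher number in this assay for the new compound. Within the data shown here, no measured compound carries a bromine, and the methyl group is gone, so the size of the step is uncertain and could be smaller or larger than that earlier one. The expected change is a 2.3-fold higher number from compound 2 to compound 3 (0.36 log units; beyond the scatter) and it remains only an estimate. For compound 3 the estimated value is 6000 nM with an expected range from 2000 nM to 18000 nM in this measurement.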

Compound 3, half-maximal inhibitory concentration: 11000 nM
The estimate for compound 3 lay 1.8-fold (0.26 log units) below the measured number, and the stated range covers the measured number.
By their numbers in this assay, from the lowest: compound 2; then compounds 1 and 3 (each within the scatter of the next).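

In this assay, 3-bromofuran-2-yl in place of 5-methylthiophen-2-yl gives a 4.2-fold higher number from compound 2 to compound 3 (0.63 log units; beyond the scatter) and so takes away the advantage that compound 2 held over compound 1, this time with a furan ring that carries a bromine and no methyl group. The direct comparison of the two furan compounds gives a 1.1-fold higher number from compound 1 to compound 3 (0.03 log units; within the scatter), so at this position on the double-bonded chain carbon, 5-methylfuran-2-yl and 3-bromofuran-2-yl cannot be told apart in this measurement. Among these three compounds, the single thiophene compound has the lowest number, with both of its steps beyond the scatter, while the two furan compounds sit level with each other; nothing measured here gives a reason for this.

The thiophene ring still appears with only one substituent, a methyl group, so a thiophene carrying a bromine would be needed to show whether the ring alone goes with the lower number. Going by these compounds, it also remains open how this position would respond to a quite different group, such as an amine or a carboxylic acid on the ring.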